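Spiro-lactam series: second ring chloro, expected central effect

A few compounds are considered here, and "the series" means these few. Any claim that something is new, unique, unknown or untested is made for them only; others in the source may bear on it.

Measured compounds:
Compound 1 `O=C1CCC2(c3ccc(F)cc3)OCCCN12` — 100 mg/kg
Compound 2 `O=C1CCC2(c3ccccc3)OCCCN12` — 150 mg/kg
Compound 3 `O=C1CCC2(c3ccc(Cl)cc3)OCCCN12` — 81.2 mg/kg

The three compounds share one core and differ only on the aromatic ring. In a functional assay on the whole organism (Central nervous system) with Mus musculus as the target (a higher number here means that more compound is needed for the effect, a lower number that less compound is needed), compound 3 gives the lowest of the three numbers, yet its steps to the others stay within the scatter: a 1.2-fold lower number from compound 1 to compound 3 (0.09 log units; within the scatter) and a 1.8-fold lower number from compound 2 to compound 3 (0.27 log units; within the scatter). The step of a 1.5-fold higher number from compound 1 to compound 2 (0.18 log units; within the scatter) is likewise within the scatter, so on these numbers the three substituents cannot be separated.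

Compound 4 `O=C1CCC2(c3ccc(Cl)c(Cl)c3)OCCCN12` has not yet been measured. Compared with compound 3 the change is chloro in place of hydrogen on an aromatic carbon. Among the measured compounds shown here, the one measured step that bears on it is the same replacement on compound 2, which gave a 1.8-fold lower number from compound 2 to compound 3 (0.27 log units; within the scatter), a change within the scatter. For the measured compounds named here, a second chloro entering ortho to the first has no precedent, so the only guide is that one step. For compound 4 the expected step in this assay is therefore a 1.2-fold lower number from compound 3 to compound 4 (0.10 log units; within the scatter), small and most likely within the scatter, leaning if anything to a lower number. Compound 4 is estimated at 65 mg/kg, with a range from 35 mg/kg to 130 mg/kg.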

Compound 4, dose for half-maximal effect: < 150 mg/kg
Compound 4: a limit, no number; the forecaster's own chance of this, stated with the estimate: 5%; the middle value lies beyond the limit too.
By their numbers in this assay, from the lowest: compounds 3, 1 and 2 (each within the scatter of the next).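

In this assay compound 4 gives < 150 mg/kg, which is a limit and not a number, so the step from compound 3 to compound 4 cannot be read. The compounds shown leave open whether a chloro ortho to a chloro group changes the dose needed for the effect relative to compound 3.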